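A few compounds are considered here, and "the series" means these few. Any claim that something is new, unique, unknown or untested is made for them only; others in the source may bear on it.

Three compounds with a shared core are compared in an assay on isolated protein for inhibition of histone deacetylase 8 (Homo sapiens), read by fluorescence, with a stated time of 17 h; on this read-out lower numbers stand for stronger inhibition and higher numbers for weaker inhibition. Compound 1, with the structure `CC(C)(C)OC(=O)Nc1cccc(-c2csc(NC(=O)CCCCCC(=O)NO)n2)c1`, carries a tert-butoxycarbonyl group on one end and a hydroxamic acid on the other; in this assay compound 1 gives 2580 nM. Compound 2, with the structure `CC(=O)Nc1cccc(-c2csc(NC(=O)CCCCCC(=O)Nc3ccccc3N)n2)c1`, is different at both ends. For compound 2 the assay reports only a limit, > 30000 nM, so no number is known for it, only that it sits at the limit of > 30000 nM in this assay, at which 1 of the 2 values shown sits. Compound 3, with the structure `CC(C)(C)OC(=O)Nc1cccc(-c2csc(NC(=O)CCCCCC(=O)Nc3ccccc3N)n2)c1`, has not been measured yet. It differs from compound 2 in one place: tert-butoxy in place of methyl on a carbonyl carbon, so the acetamido group becomes a (tert-butoxycarbonyl)amino group. Within the data shown here, no step between measured compounds is available to say what this change does in this assay. Compound 3 is expected to remain weak, with an estimated value of 30000 nM, most likely between 8000 nM and 100000 nM. The expected step from compound 2 to compound 3 is therefore a number no higher from compound 2 to compound 3 (the limit leaves the size open), close to none beyond the scatter, because compound 2 already stands at the limit > 30000 nM and there is a fair chance that compound 3 also returns only a limit.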

Compound 3, half-maximal inhibitory concentration: > 30000 nM
Compound 3: only a limit was reported (the forecaster's own chance of this, stated with the estimate: 60%); the middle value sits exactly at the limit.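

In this assay, placing 2-aminophenyl in place of hydroxy on an amide-type nitrogen, with the (tert-butoxycarbonyl)amino group left unchanged, gives an at least 11-fold higher number from compound 1 to compound 3 (1.06 log units; beyond the scatter). Among these compounds, this is the first comparison here in which only this end of the molecule changes, whereas compound 1 and compound 2 differ at both ends; the step rests on a limit for compound 3, not on a number, so it gives only the smallest size the change can have. The change from acetamido to (tert-butoxycarbonyl)amino on the 2-aminophenyl series cannot be read, because compound 2 and compound 3 both stop at the limit of the measurement: the limit of > 30000 nM in this assay, at which 2 of the 3 values shown sit.

Going by these compounds, whether the acetamido or the (tert-butoxycarbonyl)amino group makes any difference therefore remains open, and a pair carrying the hydroxamic acid at the other end would be needed to show it. Also open, on these data alone, is how a free amine or a carboxylic acid in place of the (tert-butoxycarbonyl)amino group, or a longer chain in the linker, would shift the value of compound 1.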